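From chloro to fluoro: compound 2 to compound 3

The source may hold more compounds than are shown below. What is called first, only, known or untested is meant among the compounds shown, and "the series" means these compounds.

In a functional assay on MKN-45 cells (Homo sapiens) for antiproliferative activity (a lower number here means a stronger inhibitor, a higher number a weaker inhibitor), compound 1 `COc1ccc(Nc2cccc3c2N(S(=O)(=O)c2ccc(OC)cc2)CC3)cc1` gives 487 nM and compound 2 `COc1ccc(S(=O)(=O)N2CCc3cccc(Nc4ccc(Cl)cc4)c32)cc1` gives 463 nM. These two numbers lie within the scatter of each other, so compound 2 stands level with compound 1.

Next in the series is compound 3 `COc1ccc(S(=O)(=O)N2CCc3cccc(Nc4ccc(F)cc4)c32)cc1`, with the change fluoro in place of chloro on an aromatic carbon, para to a large group. For the measured compounds named here, one measured step bears on it, at the same aromatic carbon: a 1.1-fold lower number from compound 1 to compound 2 (0.02 log units; within the scatter), for chloro in place of methoxy. Going by the values given here, no fluoro compound has been measured yet, so this single step is the only guide. On that evidence, no change beyond the scatter is expected in this assay. The expected step is a 1.1-fold higher number from compound 2 to compound 3 (0.03 log units; within the scatter). For compound 3 the estimated value is 500 nM, with an expected range of 250 nM to 1000 nM.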

Compound 3, half-maximal inhibitory concentration: 563 nM
Compound 3: middle estimate off by 1.1-fold (0.05 log units), on the low side, and the stated range covers the measured number.
By their numbers in this assay, from the lowest: compounds 2, 1 and 3 (each within the scatter of the next).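

In this assay, the aromatic carbon para to a large group now carries a third group, and fluoro stays within the scatter of both earlier groups (a 1.2-fold higher number from compound 2 to compound 3 (0.08 log units; within the scatter); a 1.2-fold higher number from compound 1 to compound 3 (0.06 log units; within the scatter)). Methoxy, chloro and fluoro therefore stand level at this carbon, so the flat result no longer rests on a single pair of compounds. No measurement shown here offers an explanation for this flat result.

As far as these compounds go, all three groups share one carbon on one core, so it remains open whether the level reading extends to a carboxylic acid, an amine or a longer alkyl chain at this carbon. From the compounds shown here alone, it also remains open whether the same three groups would stand level on the aromatic ring at other carbons or with a different sulfonyl partner.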